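A Hydroxypiperidine Replaces the Butylpiperazine Side Chain

This account rests on a few compounds, and the source may have more. Where it says the series, first, only, none or still open, it means among the compounds named here.

Of the compounds shown here, three sharing one core have been measured in a functional assay on MDA-MB-231 cells (Homo sapiens) for cytotoxicity, read by MTT assay, with a stated time of 72 h; on this read-out lower numbers stand for stronger inhibition and higher numbers for weaker inhibition. Compound 1 `CN(C)CCCCn1c2c(c3ccccc31)C(=O)c1c[n+]([O-])c3ccccc3c1C2=O` gives 350 nM, compound 2 `CN1CCN(CCCn2c3c(c4ccccc42)C(=O)c2c[n+]([O-])c4ccccc4c2C3=O)CC1` gives 390 nM, and compound 3 `CCCCN1CCN(CCCCn2c3c(c4ccccc42)C(=O)c2c[n+]([O-])c4ccccc4c2C3=O)CC1` gives 900 nM, the highest number of the three. The step of a 2.6-fold higher number from compound 1 to compound 3 (0.41 log units; beyond the scatter) and the step of a 2.3-fold higher number from compound 2 to compound 3 (0.36 log units; beyond the scatter) both set compound 3 apart, whereas the step of a 1.1-fold higher number from compound 1 to compound 2 (0.05 log units; within the scatter) stays within the scatter, so compound 1 and compound 2 cannot be ranked against each other.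

The next compound, compound 4 `O=C1c2c[n+]([O-])c3ccccc3c2C(=O)c2c1c1ccccc1n2CCCN1CCC(O)CC1`, differs from compound 3 in a single place: 4-hydroxypiperidin-1-yl in place of (4-butylpiperazin-1-yl)methyl on a saturated chain carbon, three bonds along the chain from an aromatic nitrogen. Going by the values given here, no measured step carries exactly this change. The nearest relative is the step of a 2.3-fold higher number from compound 2 to compound 3 (0.36 log units; beyond the scatter), which in the reverse direction also pares back the piperazine side chain, and the step of a 2.6-fold higher number from compound 1 to compound 3 (0.41 log units; beyond the scatter) points the same way. On that basis compound 4 is expected to give a modestly lower number than compound 3, estimated as a 2.0-fold lower number from compound 3 to compound 4 (0.30 log units; within the scatter). The estimate for compound 4 in this assay is 450 nM, with an expected range from 200 nM to 1000 nM.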

Compound 4, half-maximal inhibitory concentration: 280 nM
Compound 4: the middle estimate sits 1.6-fold (0.21 log units) above what was measured; measured number inside the range.
By their numbers in this assay, from the lowest: compounds 4, 1 and 2 (each within the scatter of the next); then compound 3.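

In this assay, putting 4-hydroxypiperidin-1-yl in place of (4-butylpiperazin-1-yl)methyl on a saturated chain carbon, three bonds along the chain from an aromatic nitrogen, gives a 3.2-fold lower number from compound 3 to compound 4 (0.51 log units; beyond the scatter), the largest step seen so far at this position. The other two steps, a 1.4-fold lower number from compound 2 to compound 4 (0.14 log units; within the scatter) and a 1.3-fold lower number from compound 1 to compound 4 (0.10 log units; within the scatter), leave compound 4 unranked against compound 2 and compound 1, so the piperazine ring is not required to reach this level: a side chain ending in 4-hydroxypiperidin-1-yl matches those ending in 4-methylpiperazin-1-yl and dimethylamino. Among the four compounds, only compound 3, with its 4-butylpiperazin-1-yl group, stands apart from the rest, and it goes against any reading that all these side chains are interchangeable.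

Nothing available here accounts for why compound 3 differs from the other three. Going by these compounds, it remains open whether the hydroxyl matters at all, which plain piperidin-1-yl would test, and whether morpholin-4-yl or 4-methoxypiperidin-1-yl would stay with compound 4 in this assay or move towards compound 3.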